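Swapping 4-fluorophenyl for pyridin-3-yl on compound 2

A few compounds are considered here, and "the series" means these few. Any claim that something is new, unique, unknown or untested is made for them only; others in the source may bear on it.

Compound 1 `O=C(Nc1ccccc1)c1cc(N2CCc3ccccc3C2)ncn1` gives < 5000 nM as a limit
Compound 2 `CN(Cc1ccc(F)cc1)c1cc(C(=O)Nc2ccccc2)ncn1` gives < 5000 nM as a limit
Compound 3 `COc1ccc(NC(=O)c2cc(N(C)Cc3cccc(F)c3)ncn2)cc1` gives 5000 nM as a number

In a physicochemical assay for solubility, using the shake flask method, measured as kinetic solubility, with a stated time of 2 h, at pH 7.4 (a higher number here means a more soluble compound, a lower number a less soluble compound), compound 2 reports only the limit < 5000 nM and no exact number. Compound 2 sits at the limit of < 5000 nM in this assay, at which 2 of the 3 values shown sit, and so has no exact place on the scale. Compound 4 `CN(Cc1cccnc1)c1cc(C(=O)Nc2ccccc2)ncn1` carries pyridin-3-yl in place of 4-fluorophenyl on a saturated chain carbon bound to a nitrogen on an aromatic ring and is still to be measured. For the measured compounds named here, no measured pair here differs in one place alone, so a modest upward move in this assay is only an expectation, estimated as an at least 2.4-fold higher number from compound 2 to compound 4 (0.38 log units; beyond the scatter) with wide uncertainty. For compound 4 the estimated value is 12000 nM with an expected range from 4000 nM to 50000 nM and a real chance of another limit.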

Compound 4, solubility: 150000 nM
Compound 4: middle estimate off by 13-fold (1.10 log units), on the low side; the measured number lies above the stated range.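

For the compounds shown here, compounds 1 to 3 contain no pair that differs in one place, so this position had no measured step until now. On a saturated chain carbon bound to a nitrogen on an aromatic ring, pyridin-3-yl in place of 4-fluorophenyl gives, in this assay, an at least 30-fold higher number from compound 2 to compound 4 (1.47 log units; beyond the scatter). This size is only a minimum, because compound 2 has a limit and no exact number: the limit of < 5000 nM in this assay, at which 2 of the 4 values shown sit.

Whether the step belongs to the ring nitrogen or to the lost fluorine stays open, as the compounds shown include no plain phenyl at this place. As far as these compounds go, how pyridin-2-yl or pyridin-4-yl would compare also stays open.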